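Swapping iodo for ethynyl in a small halogen series

The source may report more compounds than this note shows. Statements on the series, on what has been measured and on what is new or still open speak of the compounds shown alone.

Compound 1 `O=C(CCc1cccc2c1B(O)OC2)Nc1ccc(F)cc1` gives 12000 nM
Compound 2 `O=C(CCc1cccc2c1B(O)OC2)Nc1ccc(Br)cc1` gives 42000 nM
Compound 3 `O=C(CCc1cccc2c1B(O)OC2)Nc1ccc(I)cc1` gives 49000 nM

All three values come from an ADME assay on WI-38 cells (Homo sapiens) for cytotoxicity, read by MTT assay, with a stated time of 72 h; on this read-out lower numbers stand for stronger inhibition and higher numbers for weaker inhibition. Compound 3 , at 49000 nM, sits with compound 2 at the upper end of this small set, and the step between them is a 1.2-fold higher number from compound 2 to compound 3 (0.07 log units; within the scatter). Compound 1 lies clearly lower, with a step of a 4.1-fold higher number from compound 1 to compound 3 (0.61 log units; beyond the scatter).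

The next compound, compound 4 `C#Cc1ccc(NC(=O)CCc2cccc3c2B(O)OC3)cc1`, keeps the shared core and changes one group: ethynyl in place of iodo on an aromatic carbon. In words, this is ethynyl in place of iodo on an aromatic carbon, para to a large group.

Going by the values given here, no measured step brings in ethynyl, so the halogen swaps are the only guide. Moving away from fluoro produced modest steps, a 3.5-fold higher number from compound 1 to compound 2 (0.54 log units; beyond the scatter) and the one to compound 3 already given. Moving from bromo to iodo produced no step beyond the scatter. Of the three halogens, then, only fluoro stands apart, and nothing measured shows where ethynyl will fall. The expectation is therefore no step beyond the scatter in this assay, with a slight lean towards lower numbers. The expected step is a 1.4-fold lower number from compound 3 to compound 4 (0.15 log units; within the scatter). The estimated value for compound 4 is 35000 nM, with an expected range from 15000 nM to 70000 nM.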

Compound 4, half-maximal inhibitory concentration: > 100000 nM
Compound 4: no number, only a limit; the forecaster's own chance of this, stated with the estimate: 10%; middle value at least 2.8-fold (0.45 log units) away from the limit.
By their numbers in this assay, from the lowest: compound 1; then compounds 2 and 3 (each within the scatter of the next). At a limit, above all of these: compound 4.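

In this assay, compound 4 gives > 100000 nM, which is a limit of the assay and not a number: the limit of > 100000 nM in this assay, at which 1 of the 4 values shown sits.

This gives only a floor for each step, so the true steps could be larger, and the change from iodo to ethynyl reads as an at least 2.0-fold higher number from compound 3 to compound 4 (0.30 log units; that floor lies within the scatter). That floor alone does not separate ethynyl from iodo, but the comparisons with the other two halogens do separate it, with an at least 2.3-fold higher number from compound 2 to compound 4 (0.37 log units; beyond the scatter) and an at least 8.3-fold higher number from compound 1 to compound 4 (0.92 log units; beyond the scatter). The earlier compounds shown here showed only that fluoro stood apart from bromo and iodo, whereas these steps show that a group other than a halogen at this place, on the aromatic carbon para to a large group, can give a reading on the weak side of both bromo and fluoro.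

On these data alone, how far compound 4 lies past its limit remains open, and so does whether its true step from compound 3 goes beyond the scatter. Also open, as far as these compounds go, is how an amine, a carboxylic acid or a longer chain in place of ethynyl on this same carbon would read, and whether any of them would return to the range of the halogens.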